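Hydrazone-side variation on the shared core: compound 4

The compounds below may be only part of what the source reports. "The series", "measured", "known", "first", "only" and "open" are said of these compounds alone.

Compound 1, `CCOC(=O)C1=C(N/C=N/c2nnc(S(N)(=O)=O)s2)Nc2[nH]nc(C)c2C1c1ccc(N(C)C)cc1`, in a functional assay on HepG2 cells (Homo sapiens) for inhibition, read by MTT assay, with a stated time of 48 h (a lower number here means a stronger inhibitor, a higher number a weaker inhibitor), gives 38100 nM.
Compound 2, `CCOC(=O)C1=C(N/N=C(/C(C)=O)C(=O)OCC)Nc2[nH]nc(C)c2C1c1ccc(N(C)C)cc1`, in this assay reaches only the assay limit > 100000 nM.
Compound 3, `CCOC(=O)C1=C(N/N=C(/C(=O)Br)c2ccc(Br)cc2)Nc2[nH]nc(C)c2C1c1ccc(N(C)C)cc1`, in this assay gives 65000 nM.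

Among the measured compounds shown here, compound 3 and compound 1 sit within the scatter of each other, a 1.7-fold higher number from compound 1 to compound 3 (0.23 log units; within the scatter); the only other number is the limit of compound 2, (the limit of > 100000 nM in this assay, at which 1 of the 3 values shown sits).

Compound 4, `CCOC(=O)C1=C(N/N=C(/Cl)c2ccc([N+](=O)[O-])cc2)Nc2[nH]nc(C)c2C1c1ccc(N(C)C)cc1`, differs from compound 3 at the group on the amine nitrogen: a group of 12 heavy atoms (7 carbon, 2 nitrogen, 2 oxygen, 1 chlorine; one six-membered aromatic ring of carbon only) in place of a group of 12 heavy atoms (8 carbon, 1 nitrogen, 1 oxygen, 2 bromine; one six-membered aromatic ring of carbon only), on an amine nitrogen. The steps that touch this position are a 1.7-fold higher number from compound 1 to compound 3 (0.23 log units; within the scatter), within the scatter, and an at least 1.5-fold lower number from compound 2 to compound 3 (0.18 log units; that floor lies within the scatter), whose floor lies within the scatter; only an at least 2.6-fold higher number from compound 1 to compound 2 (0.41 log units; beyond the scatter) goes beyond it. The change to compound 4 keeps an aromatic ring, so no step beyond the scatter is expected in this assay.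

Compound 4 is therefore expected at 60000 nM, between 25000 nM and 150000 nM, an estimated 1.1-fold lower number from compound 3 to compound 4 (0.03 log units; within the scatter).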

Compound 4, half-maximal inhibitory concentration: 55500 nM
Compound 4: middle estimate off by 1.1-fold (0.03 log units), on the high side; measured number inside the range.
By their numbers in this assay, from the lowest: compounds 1, 4 and 3 (each within the scatter of the next). At a limit, above all of these: compound 2.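

In this assay, the chlorine-bearing group on the amine nitrogen gives no separation from the two-bromine group, a 1.2-fold lower number from compound 3 to compound 4 (0.07 log units; within the scatter), or from the five-membered aromatic ring group, a 1.5-fold higher number from compound 1 to compound 4 (0.16 log units; within the scatter), so three different ring-bearing groups now lie within the scatter of their neighbours. Against the ring-free group the step is an at least 1.8-fold lower number from compound 2 to compound 4 (0.25 log units; that floor lies within the scatter), so this comparison also shows no separation beyond the scatter. Compound 2 remains a limit, not a number: the limit of > 100000 nM in this assay, at which 1 of the 4 values shown sits.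

Going by these compounds, whether an amine or a carboxylic acid in this group would give a step beyond the scatter remains open.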